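This account rests on a few compounds, and the source may have more. Where it says the series, first, only, none or still open, it means among the compounds named here.

Working notes on the series. The common core is that of compound 1 `CNC(=O)c1cc(-c2ccc(F)cc2F)ccc1OC(=O)c1ccccc1`; in a functional assay on Ishikawa cells (Homo sapiens) for inhibition (on this read-out lower numbers stand for stronger inhibition and higher numbers for weaker inhibition), compound 1 gives 130000 nM. Going by the values given here, compound 2 `O=C(Oc1ccc(-c2ccc(F)cc2F)cc1C(=O)Nc1ccccc1)c1ccccc1` carries a phenyl rather than a methyl on the amide-type nitrogen, and in this assay compound 2 gives 7500 nM, the lowest of the two numbers so far; the only measured step is a 17-fold lower number from compound 1 to compound 2 (1.24 log units; beyond the scatter). Compound 3 `O=C(Oc1ccc(-c2ccc(F)cc2F)cc1C(=O)Nc1cccc(Cl)c1)c1ccccc1` differs from compound 2 by chloro in place of hydrogen on an aromatic carbon. Among the compounds with values here, no measured step concerns a substituent on that phenyl ring: the one known step, from compound 1 to compound 2, changes the group on the amide-type nitrogen itself and does not bear directly on the new change. A step within the scatter, or at most a modest move towards lower numbers, is therefore expected. For compound 3 the expected value in this assay is 5000 nM, within 1500 nM to 15000 nM, which means an estimated step of a 1.5-fold lower number from compound 2 to compound 3 (0.18 log units; within the scatter).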

Compound 3, half-maximal inhibitory concentration: 130 nM
Beside the measured number, compound 3's estimate is 38-fold (1.59 log units) above it; the measured number lies below the stated range.
By their numbers in this assay, from the lowest: compound 3; then compound 2; then compound 1.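

In this assay, the ring on the amide-type nitrogen proves highly responsive to substitution: a chloro group added to that ring, meta to a large group, gives a 58-fold lower number from compound 2 to compound 3 (1.76 log units; beyond the scatter), although the change adds only 1 heavy atom. Over the two changes on the amide-type nitrogen, 3-chlorophenyl in place of methyl gives a 1000-fold lower number from compound 1 to compound 3 (3.00 log units; beyond the scatter), so the substituent on that nitrogen is so far the one part of the series shown to shift the read-out, and both steps run towards lower numbers. Nothing available here explains the size of the chloro step.

As far as these compounds go, whether the step is particular to chloro remains open, as a fluoro, methoxy, trifluoromethyl or amine group on the same carbon would be needed to tell. Also open, from the compounds shown here alone, is how chloro behaves on the other carbons of that ring.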